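The source may report more compounds than this note shows. Statements on the series, on what has been measured and on what is new or still open speak of the compounds shown alone.

Among the compounds with values here, compound 1 `O=C(Nc1ccccc1)c1csc(-c2cn(Cc3ccc(Cl)cc3)c3ccccc23)n1` is the only member of this set with a numerical result: in a functional assay on HeLa cells (Homo sapiens) for cytotoxicity, read by MTT assay, with a stated time of 48 h, in the presence of a further agent that is not named here (on this read-out lower numbers stand for stronger inhibition and higher numbers for weaker inhibition), compound 1 gives 32100 nM. Compound 2 `COc1cc(NC(=O)c2csc(-c3cn(Cc4ccc(Cl)cc4)c4ccccc34)n2)cc(OC)c1OC` carries a 3,4,5-trimethoxyphenyl in place of phenyl on an amide-type nitrogen; in this assay compound 2 reaches only the limit of the assay, > 100000 nM. The step of an at least 3.1-fold higher number from compound 1 to compound 2 (0.49 log units; beyond the scatter) is therefore beyond the scatter, resting on (the limit of > 100000 nM in this assay, at which 1 of the 2 values shown sits). Compound 3 `O=C(Nc1ccccc1)c1csc(-c2c[nH]c3ccccc23)n1` differs from compound 1 at another place: hydrogen in place of 4-chlorobenzyl on an aromatic nitrogen. As far as these compounds go, neither measured step touches this aromatic nitrogen, so nothing measured bears on the change and its direction remains open. Since compound 1 already sits at 32100 nM, any further weakening would place compound 3 well into the weak range of this read-out. Compound 3 is expected to give 60000 nM, between 20000 nM and 180000 nM. The step of a 1.9-fold higher number from compound 1 to compound 3 (0.27 log units; within the scatter) is expected to be modest, toward weaker inhibition.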

Compound 3, half-maximal inhibitory concentration: > 100000 nM
Compound 3 gave a limit, no number; the forecaster's own chance of this, stated with the estimate: 35%; middle value at least 1.6-fold (0.22 log units) away from the limit.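

Taking the 4-chlorobenzyl off the aromatic nitrogen is the first change shown at this position, and in this assay it gives an at least 3.1-fold higher number from compound 1 to compound 3 (0.49 log units; beyond the scatter), so this substituent does bear on the read-out and not only the group on the amide-type nitrogen. For compound 3 the entry > 100000 nM is a limit of the assay and not a number. The step is therefore a lower bound only, and its true size cannot be read: the limit of > 100000 nM in this assay, at which 2 of the 3 values shown sit.

The compounds shown leave open which part of the 4-chlorobenzyl counts, that is, whether a plain benzyl without the chlorine, a methyl or a longer alkyl chain on this nitrogen would stay near compound 1 at 32100 nM. They also leave open whether a fluorine or a methoxy in place of the chlorine would do the same.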